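Swapping an aryl group on a urea-linked hydrazone

A few compounds are considered here, and "the series" means these few. Any claim that something is new, unique, unknown or untested is made for them only; others in the source may bear on it.

Measured compounds:
Compound 1, `O=C(N/N=C/c1cccc(Br)c1)Nc1cc2c(Nc3ccc(F)c(Cl)c3)ncnc2cc1O[C@H]1CCOC1`, gives 10700 nM in a functional assay on A549 cells (Homo sapiens) for cytotoxicity, read by MTT assay, with a stated time of 72 h; on this read-out lower numbers stand for stronger inhibition and higher numbers for weaker inhibition.
Compound 2, `N#Cc1ccc(/C=N/NC(=O)Nc2cc3c(Nc4ccc(F)c(Cl)c4)ncnc3cc2O[C@H]2CCOC2)cc1`, gives 29100 nM.
Compound 3, `COc1cc2ncnc(Nc3ccc(F)c(Cl)c3)c2cc1NC(=O)N/N=C/c1cccc(Br)c1`, gives 28100 nM.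

Compound 4, `COc1cc2ncnc(Nc3ccc(F)c(Cl)c3)c2cc1NC(=O)N/N=C/c1ccc(C#N)cc1`, is not yet measured. It differs from compound 3 by 4-cyanophenyl in place of 3-bromophenyl on a carbon with a double bond to nitrogen. The same change has already been made once, from compound 1 to compound 2, where it gave a 2.7-fold higher number from compound 1 to compound 2 (0.43 log units; beyond the scatter). The two starting points are not identical, though: the cores differ by methyl in place of oxolan-3-yl on an oxygen on an aromatic ring, a change that on its own gave a 2.6-fold higher number from compound 1 to compound 3 (0.42 log units; beyond the scatter).

Because the same change at the same place gave a 2.7-fold higher number from compound 1 to compound 2 (0.43 log units; beyond the scatter), the step from compound 3 to compound 4 is expected to be of a similar size, a 2.3-fold higher number from compound 3 to compound 4 (0.36 log units; beyond the scatter), with added uncertainty from the different core. Compound 4 is therefore estimated at 65000 nM, expected to fall between 25000 nM and 170000 nM.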

Compound 4, half-maximal inhibitory concentration: 32200 nM
Compound 4: the middle estimate sits 2.0-fold (0.31 log units) above what was measured, within the range that was stated.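

In this assay, putting 4-cyanophenyl in place of 3-bromophenyl gave a 1.1-fold higher number from compound 3 to compound 4 (0.06 log units; within the scatter), and putting methyl in place of oxolan-3-yl on the oxygen gave a 1.1-fold higher number from compound 2 to compound 4 (0.04 log units; within the scatter). The first change can therefore be carried from one core to the other without a gap that stands out from the scatter: the same change on two cores in this assay, a 2.7-fold higher number (0.43 log units; beyond the scatter) from compound 1 to compound 2 and a 1.1-fold higher number (0.06 log units; within the scatter) from compound 3 to compound 4, 2.4-fold (0.38 log units) apart, within the scatter of two such steps The same is true of the second change, but this does not show that either step keeps its size, as each is beyond the scatter on one core and within it on the other: the same change on two cores in this assay, a 2.6-fold higher number (0.42 log units; beyond the scatter) from compound 1 to compound 3 and a 1.1-fold higher number (0.04 log units; within the scatter) from compound 2 to compound 4, 2.4-fold (0.38 log units) apart, within the scatter of two such steps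

On these data alone, whether a phenyl ring bearing an amine or a carboxylic acid would behave in the same way remains open. So does the effect of a longer chain on the oxygen.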